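Changing the Side-Chain Carbonyl Group on a Shared Core

This account rests on a few compounds, and the source may have more. Where it says the series, first, only, none or still open, it means among the compounds named here.

Measured so far, in a functional assay on SK-BR-3 cells (Homo sapiens) for antiproliferative activity, read by MTT assay, with a stated time of 72 h; on this read-out lower numbers stand for stronger inhibition and higher numbers for weaker inhibition:
compound 1, `C/C=C1/[C@H](O[C@@H]2O[C@H](CO)[C@@H](O)[C@H](O)[C@H]2O)OC=C(C(=O)OC)[C@H]1CC(=O)NCCC`, gives > 20000 nM.
compound 2, `C/C=C1/[C@H](O[C@@H]2O[C@H](COC(C)=O)[C@@H](OC(C)=O)[C@H](OC(C)=O)[C@H]2OC(C)=O)OC=C(C(=O)OC)[C@H]1CC(=O)O`, gives > 15000 nM.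
compound 3, `C/C=C1/[C@H](O[C@@H]2O[C@H](COC(C)=O)[C@@H](OC(C)=O)[C@H](OC(C)=O)[C@H]2OC(C)=O)OC=C(C(=O)OC)[C@H]1CC(=O)SCCC`, gives > 15000 nM.

Each of these three numbers is a limit of this assay, not a measured value. Compound 1 sits at the limit of > 20000 nM in this assay, at which 1 of the 3 values shown sits. Compound 2 and compound 3 both sit at the limit of > 15000 nM in this assay, at which 2 of the 3 values shown sit. Compound 1 therefore stands nowhere in particular among the values shown: all three compounds failed to reach the read-out within the range tested, so none can be called weaker or stronger than another.

For the measured compounds named here, only one measured pair differs in a single place, and its step is a step that the two limits leave unreadable from compound 2 to compound 3. Since both ends are limits, that step says nothing about how exchanging the group on the carbonyl carbon moves the read-out.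

Compound 4, `C/C=C1/[C@H](O[C@@H]2O[C@H](CO)[C@@H](O)[C@H](O)[C@H]2O)OC=C(C(=O)OC)[C@H]1CC(=O)OCc1ccc(OC)c(OC)c1`, is the next compound to be measured in this assay. It differs from compound 1 by (3,4-dimethoxybenzyl)oxy in place of propylamino on a carbonyl carbon. Going by the values given here, no measured step bears on a change of this kind, and the only neighbouring step is unreadable. With nothing pointing in either direction, the expectation is that compound 4 stays close to where compound 1 sits, a step of an at least 1.3-fold lower number from compound 1 to compound 4 (0.12 log units; that floor lies within the scatter). The estimated value for compound 4 in this assay is 15000 nM, within a range from 3000 nM to 40000 nM.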

Compound 4, half-maximal inhibitory concentration: > 15000 nM
Compound 4 ended at the assay's limit (the forecaster's own chance of this, stated with the estimate: 60%); the middle value sits exactly at the limit.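

In this assay compound 4 gives > 15000 nM, which is a limit of the assay. Compound 1 gives > 20000 nM, also a limit, so the step from compound 1 to compound 4 cannot be read. The compounds shown leave open whether any group on this carbonyl carbon changes antiproliferative activity at all.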